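Methyl for hydrogen, twice, in a cytotoxicity series

This account rests on a few compounds, and the source may have more. Where it says the series, first, only, none or still open, it means among the compounds named here.

Compound 2 `CC(C)C[C@H](NC(=O)[C@H](C)N)B(O)O` gives 3200 nM in an ADME assay on FSCLL cells (Homo sapiens) for cytotoxicity, read by MTT assay, with a stated time of 24 h; on this read-out lower numbers stand for higher toxicity in this test and higher numbers for lower toxicity in this test. Compound 1 `CC[C@H](N)C(=O)N[C@@H](CC(C)C)B(O)O` gives 1500 nM in this assay and carries one more carbon: methyl in place of hydrogen on a saturated chain carbon, two bonds along the chain from an amine nitrogen and a carbonyl carbon. That change reads a 2.1-fold lower number from compound 2 to compound 1 (0.33 log units; beyond the scatter). Compound 3 `CC(C)C[C@H](NC(=O)[C@H](CO)NC(=O)c1cnccn1)B(O)O` gives 210 nM in this assay and stands lowest of the three numbers; the difference between its core and the core of compound 2 is not broken down here. Compound 4 `CC(C)C[C@H](NC(=O)[C@@H](NC(=O)c1cnccn1)[C@@H](C)O)B(O)O` is not yet measured. It differs from compound 3 by methyl in place of hydrogen on a saturated chain carbon bound to an oxygen on a saturated carbon and a saturated chain carbon. This is the same kind of change as from compound 2 to compound 1, not the same: there the place was a saturated chain carbon two bonds along the chain from an amine nitrogen and a carbonyl carbon, here it is a saturated chain carbon bound to an oxygen on a saturated carbon and a saturated chain carbon. The expectation for compound 4 rests on a 2.1-fold lower number from compound 2 to compound 1 (0.33 log units; beyond the scatter) and is weighted down: the place differs. For compound 4 the estimated value in this assay is 140 nM, between 60 nM and 350 nM. The step expected for compound 4 is a 1.5-fold lower number from compound 3 to compound 4 (0.18 log units; within the scatter), a modest one.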

Compound 4, half-maximal cytotoxic concentration: 100 nM
For compound 4 the middle estimate is 1.4-fold (0.15 log units) above the measured one; low and high end bracket the measured number.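

In this assay, methyl in place of hydrogen on the hydroxymethyl group gives a 2.1-fold lower number from compound 3 to compound 4 (0.32 log units; beyond the scatter), and set beside the earlier step, the two agree: the same change on two cores in this assay, a 2.1-fold lower number (0.33 log units; beyond the scatter) from compound 2 to compound 1 and a 2.1-fold lower number (0.32 log units; beyond the scatter) from compound 3 to compound 4, 1.0-fold (0.01 log units) apart, within the scatter of two such steps

On these two cores, the change therefore carries over in direction and size, even though the place differs: a saturated chain carbon two bonds along the chain from an amine nitrogen and a carbonyl carbon in one, and a saturated chain carbon bound to an oxygen on a saturated carbon and a saturated chain carbon in the other. This agreement rests on two pairs only and does not show that the step would hold on any other core in the series, nor does it give a reason for the step.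

The compounds shown leave open whether a longer chain in place of the methyl of the 1-hydroxyethyl group would continue the step. They also leave open whether an amine in place of the hydroxyl of compound 4 would preserve it.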